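The source may hold more compounds than are shown below. What is called first, only, known or untested is meant among the compounds shown, and "the series" means these compounds.

Measured in a functional assay on NCI-H460 cells (Homo sapiens) for inhibition, read by CCK-8 assay, with a stated time of 72 h, tested at 10 uM; a lower number here means less inhibition of growth, a higher number more inhibition of growth at the concentration tested:

Compound 1 `CN(C)C(=O)c1cc2cnc(Nc3ccc(N)cn3)nc2n1C1CCCC1`: 62%
Compound 2 `CN(C)C(=O)c1cc2cnc(Nc3ccc(NC(=O)C4(C(=O)Nc5cccc(F)c5)CC4)cc3)nc2n1C1CCCC1`: 98.8%
Compound 3 `Nc1ccc(NC(=O)C2(C(=O)Nc3ccc(F)cc3)CC2)cc1F`: 62.9%

Compound 2 stands highest of these three, and compound 1 and compound 3 each lie below it by more than the usual scatter of repeated measurements. At the single concentration tested, compound 2 gives 98.8%, which is close to complete inhibition of growth.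

Compound 4 `CN(C)C(=O)c1cc2cnc(Nc3ccc(NC(=O)C4(C(=O)Nc5ccc(Cl)c(C(F)(F)F)c5)CC4)cc3)nc2n1C1CCCC1` has not yet been measured. It carries 4-chloro-3-(trifluoromethyl)phenyl in place of 3-fluorophenyl on an amide-type nitrogen. The rest of compound 2 stays as it is.

For the measured compounds named here, no two measured compounds differ in only one place, so the data hold no direct example of what a change like this does in this assay. The expectation therefore rests mainly on the starting point. Compound 2 at 98.8% leaves almost no room for a rise, so any real movement is more likely to be downward. The expected change is small and within the scatter, estimated as a number 4.8 percentage points lower from compound 2 to compound 4 (within the scatter). For compound 4 the estimated value is 94%, with an expected range of 78% to 104%.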

Compound 4, percent growth inhibition at one concentration: 91.9%
For compound 4 the middle estimate is 2.1 percentage points above the measured one; low and high end bracket the measured number.
By their numbers in this assay, from the lowest: compounds 1 and 3 (each within the scatter of the next); then compounds 4 and 2 (each within the scatter of the next).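

For the compounds shown here, the step of a number 6.9 percentage points lower from compound 2 to compound 4 (within the scatter) in this assay gives the first direct comparison at this position, the aromatic ring on the amide-type nitrogen. It shows that this position accepts 4-chloro-3-(trifluoromethyl)phenyl, with 11 heavy atoms, as well as 3-fluorophenyl, with 7, and that the added chlorine and the trifluoromethyl group leave growth inhibition at this concentration close to complete. No measurement of any property of these groups is at hand to explain this result.

What the compounds shown leave open is whether this position needs an aromatic ring at all, for example whether a cyclohexyl ring or a short chain ending in an amine would give a similar number in this assay. Compound 2 and compound 4 both lie near the top of the scale at a single concentration, and whether a difference between them would appear at lower concentrations remains an open question.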